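A Chloro Group on the Furan Ring of Compound 3

The compounds below may be only part of what the source reports. "The series", "measured", "known", "first", "only" and "open" are said of these compounds alone.

Compound 1, `CN(C)Cc1cc2c(N)nc(-c3ccco3)nc2s1`: 3550 nM
Compound 2, `Nc1nc(-c2ccco2)nc2sc(CN3CCC(=O)CC3)cc12`: 2720 nM
Compound 3, `Nc1nc(-c2ccco2)nc2sc(CN3CC=CC3)cc12`: 290 nM

In an assay on CHO-K1 cells for antagonist activity at adenosine receptor A1 (Homo sapiens), read by a beta-galactosidase reporter, with stated times of 15 min and 6 h (a higher number here means a weaker inhibitor, a lower number a stronger inhibitor), compound 3 stands at the lowest of the three numbers. Its nearest neighbour is compound 2, with the step of a 9.4-fold lower number from compound 2 to compound 3 (0.97 log units; beyond the scatter); the step of a 12-fold lower number from compound 1 to compound 3 (1.09 log units; beyond the scatter) is larger still. Both measured steps, and also a 1.3-fold lower number from compound 1 to compound 2 (0.12 log units; within the scatter), change only the group on the saturated chain carbon bound to an aromatic carbon; none touches the furan ring. Compound 4, `Nc1nc(-c2ccc(Cl)o2)nc2sc(CN3CC=CC3)cc12`, differs from compound 3 exactly there: chloro in place of hydrogen on an aromatic carbon. For the measured compounds named here, no measured step bears on this change, so the expectation rests on compound 3 alone, at 290 nM, and the expected step is a 1.1-fold lower number from compound 3 to compound 4 (0.05 log units; within the scatter), none beyond the scatter. Compound 4 is therefore estimated at 260 nM, with a range from 70 nM to 950 nM.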

Compound 4, inhibition constant: 780 nM
Compound 4: middle estimate off by 3.0-fold (0.48 log units), on the low side; low and high end bracket the measured number.
By their numbers in this assay, from the lowest: compound 3; then compound 4; then compounds 2 and 1 (each within the scatter of the next).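

The earlier compounds shown here changed only the group on the saturated chain carbon, so they said nothing about the furan ring. In this assay, this change shows that the ring also affects the number: placing chloro next to the ring oxygen, in the step from furan-2-yl to 5-chlorofuran-2-yl, gives a modest weakening (a 2.7-fold higher number from compound 3 to compound 4 (0.43 log units; beyond the scatter)). Nothing available accounts for this weakening.

From the compounds shown here alone, it remains open whether methyl, bromo or methoxy at this place would give a similar step. Also open, going by these compounds, is whether chloro would do the same alongside the dimethylamino group of compound 1 or the 4-oxopiperidin-1-yl group of compound 2.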